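Triazole variations at the ether-linked methylene

The source may report more compounds than this note shows. Statements on the series, on what has been measured and on what is new or still open speak of the compounds shown alone.

Measured compounds:
compound 1 `CCC(C)(C)Cc1c[nH]c(CCc2ccc(-c3ccccc3OCc3nc(N)n[nH]3)cc2)n1`, 78 nM
compound 2 `CCC(C)(C)Cc1c[nH]c(CCc2ccc(-c3ccccc3OCc3nc(=O)[nH][nH]3)cc2)n1`, 336 nM

In a functional assay for agonist activity at Bombesin receptor subtype-3 (Homo sapiens) (a higher number here means that more compound is needed for the effect, a lower number that less compound is needed), compound 2 gives the higher of the two numbers; its nearest neighbour is compound 1, and the gap a 4.3-fold higher number from compound 1 to compound 2 (0.63 log units; beyond the scatter) lies beyond the scatter. Compound 3 `CCC(C)(C)Cc1c[nH]c(CCc2ccc(-c3ccccc3OCc3cnn[nH]3)cc2)n1` differs from compound 2 by a group of 5 heavy atoms (2 carbon, 3 nitrogen; one five-membered aromatic ring with 3 hetero atoms) in place of a group of 6 heavy atoms (2 carbon, 3 nitrogen, 1 oxygen; one five-membered aromatic ring with 3 hetero atoms), on a saturated chain carbon bound to an oxygen on an aromatic ring. Among the measured compounds shown here, the only step that bears on this change is a 4.3-fold higher number from compound 1 to compound 2 (0.63 log units; beyond the scatter), in which the oxo-bearing ring of compound 2 gave the weaker result. A step back toward compound 1, though smaller, is expected, as a 2.1-fold lower number from compound 2 to compound 3 (0.32 log units; beyond the scatter). For compound 3 the expected value in this assay is 160 nM, within 55 nM to 480 nM.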

Compound 3, half-maximal effective concentration: 399 nM
Beside the measured number, compound 3's estimate is 2.5-fold (0.40 log units) below it; measured number inside the range.
By their numbers in this assay, from the lowest: compound 1; then compounds 2 and 3 (each within the scatter of the next).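

In this assay, the oxo-bearing ring and the 1H-1,2,3-triazol-5-yl ring cannot be told apart: a 1.2-fold higher number from compound 2 to compound 3 (0.07 log units; within the scatter). Against the 3-amino-1H-1,2,4-triazol-5-yl ring, the step is a 5.1-fold higher number from compound 1 to compound 3 (0.71 log units; beyond the scatter), so compound 1 now stands apart from two other rings rather than one. No measurement on hand accounts for this. Still open, from the compounds shown here alone, is whether the gap follows the amino group or the ring's arrangement of nitrogens. An unsubstituted 1H-1,2,4-triazol-5-yl ring, or a methyl group in place of the amino group, would bear on this.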